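The source may hold more compounds than are shown below. What is called first, only, known or untested is meant among the compounds shown, and "the series" means these compounds.

Measured so far in an assay on isolated protein for inhibition of thiosulfate sulfurtransferase (Homo sapiens), with a stated time of 60 min, in the absence of a further agent; on this read-out lower numbers stand for stronger inhibition and higher numbers for weaker inhibition:

compound 1, `COc1ccc(Br)cc1C(=O)Nc1ccc(Sc2nc3ccccc3s2)cc1`: > 100000 nM, a limit of the assay and not a number.
compound 2, `O=C(Nc1ccc(Sc2nc3ccccc3s2)c(Cl)c1)c1cc(Br)cc(Br)c1`: > 100000 nM, likewise only a limit.
compound 3, `O=C(Nc1cccc(Cl)c1)c1cc(Br)cc(Br)c1`: > 100000 nM, likewise only a limit.

Among the measured compounds shown here, compound 1 therefore stands nowhere on a scale: its value in this assay is a limit, and the same holds for compound 2 and compound 3, so that no measured step between any two of them can be read, and the whole set is summed up by the limit of > 100000 nM in this assay, at which 3 of the 3 values shown sit.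

Compound 4, `COc1c(Br)cccc1C(=O)Nc1ccc(Sc2nc3ccccc3s2)cc1`, is not yet measured. It keeps the shared core of compound 1 and differs by a group of 9 heavy atoms (7 carbon, 1 oxygen, 1 bromine; one six-membered aromatic ring of carbon only) in place of a group of 9 heavy atoms (7 carbon, 1 oxygen, 1 bromine; one six-membered aromatic ring of carbon only), on a carbonyl carbon: the 5-bromo-2-methoxyphenyl leaves and a group with no common name, built from the same atoms, takes its place on the carbonyl carbon next to the amide-type nitrogen.

For the measured compounds named here, with three limits and no measured step to lean on, nothing in the data points to a gain from this rearrangement. The step from compound 1 to compound 4 in this assay is expected to be a number no higher from compound 1 to compound 4 (the limit leaves the size open), that is none beyond the scatter. Compound 4 is estimated at 100000 nM, in the range 30000 nM to 300000 nM, most likely reported again as a limit.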

Compound 4, half-maximal inhibitory concentration: > 100000 nM
Compound 4 ended at the assay's limit; the forecaster's own chance of this, stated with the estimate: 80%; the middle value sits exactly at the limit.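

Compound 1 and compound 4 both stand only at a limit of the assay and not at a number, and the step between them cannot be read. The compounds shown leave open which change, if any, would bring a measurable value in this assay: the limit of > 100000 nM in this assay, at which 4 of the 4 values shown sit.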